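Swapping 4-bromophenyl for 2,4-dimethylphenyl on a sulfonamide

The source may report more compounds than this note shows. Statements on the series, on what has been measured and on what is new or still open speak of the compounds shown alone.

Of the compounds shown here, three with a shared core have been measured so far. In a functional assay on M21 cells (Homo sapiens) for antiproliferative activity, read by sulforhodamine B assay, with a stated time of 48 h (a lower number here means a stronger inhibitor, a higher number a weaker inhibitor), compound 1 `O=C1NCCN1c1ccc(S(=O)(=O)Nc2ccccc2)cc1` gives 200 nM while compound 2 `O=C1NCCN1c1ccc(S(=O)(=O)Nc2ccc(Cl)cc2)cc1` gives 90 nM and compound 3 `O=C1NCCN1c1ccc(S(=O)(=O)Nc2ccc(Br)cc2)cc1` gives 130 nM in the same test. Compound 3 lies within the usual scatter of both others and cannot be ranked against either.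

Compound 4 `Cc1ccc(NS(=O)(=O)c2ccc(N3CCNC3=O)cc2)c(C)c1` has 2,4-dimethylphenyl in place of 4-bromophenyl on a sulfonamide nitrogen. Among the measured compounds shown here, the only measured steps that bear on this swap are halogen changes on that same group: chloro in place of hydrogen gives a 2.2-fold lower number from compound 1 to compound 2 (0.35 log units; beyond the scatter) while bromo in place of hydrogen gives a 1.5-fold lower number from compound 1 to compound 3 (0.19 log units; within the scatter) and bromo in place of chloro gives a 1.4-fold higher number from compound 2 to compound 3 (0.16 log units; within the scatter) here. For the measured compounds named here, no measured compound carries a methyl group, which makes this evidence indirect.

Starting from compound 3 at 130 nM in this assay and given steps this small, no change beyond the scatter is expected. The estimated step is a 1.2-fold higher number from compound 3 to compound 4 (0.06 log units; within the scatter) for now. Compound 4 is expected near 150 nM with an estimated range from 50 nM to 450 nM in this test.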

Compound 4, half-maximal inhibitory concentration: 150 nM
Compound 4: middle estimate and measured number agree at the digits printed; the range from low to high includes it.
By their numbers in this assay, from the lowest: compounds 2, 3, 4 and 1 (each within the scatter of the next, the first and the last beyond it).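

In this assay, among the compounds shown here, compound 4 is the first compound here with methyl groups rather than a halogen on the aromatic ring, and it cannot be separated from any of the three earlier compounds (a 1.2-fold higher number from compound 3 to compound 4 (0.06 log units; within the scatter); a 1.7-fold higher number from compound 2 to compound 4 (0.22 log units; within the scatter); a 1.3-fold lower number from compound 1 to compound 4 (0.12 log units; within the scatter)). The group on the sulfonamide nitrogen can therefore carry two methyl groups, and no halogen is needed for a number in this range. Compound 4 lies within the scatter of both compound 1 and compound 2, although those two lie beyond the scatter of each other, so it cannot be grouped with either.

As far as these compounds go, whether a single methyl group would behave the same way stays open, as does the outcome with an amine, a carboxylic acid or a longer chain on this ring. No measurement shown here offers an explanation for this result.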